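Shifting a Methoxy Group on an Amide-Linked Phenyl Ring

A few compounds are considered here, and "the series" means these few. Any claim that something is new, unique, unknown or untested is made for them only; others in the source may bear on it.

Compound 2 `COc1ccccc1C(=O)Nc1cccc(-c2oc3cc(-c4ccc(F)cc4)ccc3c(=O)c2O)c1` is the weaker of the two measured compounds in a functional assay on A549 cells (Homo sapiens) for antiproliferative activity, read by CCK-8 assay, with a stated time of 72 h (a lower number here means a stronger inhibitor, a higher number a weaker inhibitor), where compound 2 gives 11700 nM. Its nearest neighbour, compound 1 `O=C(Nc1cccc(-c2oc3cc(-c4ccc(F)cc4)ccc3c(=O)c2O)c1)c1ccccc1F`, differs only by carrying fluoro where compound 2 carries methoxy; in this assay compound 1 gives 4410 nM, and the step of a 2.7-fold higher number from compound 1 to compound 2 (0.42 log units; beyond the scatter) shows that this exchange weakened inhibition by a modest amount. Compound 3 `COc1cccc(C(=O)Nc2cccc(-c3oc4cc(-c5ccc(F)cc5)ccc4c(=O)c3O)c2)c1` keeps all the atoms of compound 2 but joins them differently: 3-methoxyphenyl in place of 2-methoxyphenyl on a carbonyl carbon. Among the compounds with values here, no measured pair shows this kind of rearrangement, so only the single step of a 2.7-fold higher number from compound 1 to compound 2 (0.42 log units; beyond the scatter) offers guidance; it indicates that the group on this carbonyl-linked ring matters, yet it says nothing about where on that ring a methoxy is best placed. A modest step in either direction is therefore possible, and the expected change a 1.6-fold lower number from compound 2 to compound 3 (0.19 log units; within the scatter) is taken as small. Compound 3 is expected to give about 7500 nM, with a likely range from 2500 nM to 22000 nM.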

Compound 3, half-maximal inhibitory concentration: 10800 nM
The estimate for compound 3 lay 1.4-fold (0.16 log units) below the measured number; the range from low to high includes it.
By their numbers in this assay, from the lowest: compound 1; then compounds 3 and 2 (each within the scatter of the next).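

Moving the methoxy on the carbonyl carbon, 3-methoxyphenyl in place of 2-methoxyphenyl, gives a 1.1-fold lower number from compound 2 to compound 3 (0.03 log units; within the scatter) in this assay, so this assay cannot separate these two placements of the group. With 3-methoxyphenyl in place of 2-fluorophenyl, the result is a 2.4-fold higher number from compound 1 to compound 3 (0.39 log units; beyond the scatter), a modest change. The methoxy compounds therefore both give higher numbers than the fluoro compound, and this gap does not rest on a single placement of the methoxy.

Still open, as far as these compounds go, is whether another group on this ring, such as an amine or a carboxylic acid, would give a lower number than compound 1 at 4410 nM, and whether moving the fluoro would matter more than moving the methoxy. No measurement available here explains why these numbers fall as they do.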